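The compounds below may be only part of what the source reports. "The series", "measured", "known", "first", "only" and "open" are said of these compounds alone.

Compound 1 `O=C(CSc1snnc1-c1ccc(Br)cc1Br)Nc1nccs1` and compound 2 `Cc1ccc(NC(=O)CSc2snnc2-c2ccc(Br)cc2Br)c(Br)c1` share a core and differ only in the group on the amide nitrogen. In an ADME assay on MT4 cells (Homo sapiens) for cytotoxicity, read by MTT assay, with a stated time of 5 days (on this read-out higher numbers stand for lower toxicity in this test and lower numbers for higher toxicity in this test), compound 1 gives 87800 nM. Compound 2 reaches only the assay's limit of > 216000 nM, so no exact number is known for it, and its step of an at least 2.4-fold higher number from compound 1 to compound 2 (0.39 log units; beyond the scatter) is therefore also only a lower bound, as the limit of > 216000 nM in this assay, at which 1 of the 2 values shown sits, records. Compound 3 `Cc1ccc(NC(=O)CSc2snnc2-c2ccc(Br)cc2Br)cc1` differs from compound 2 by hydrogen in place of bromo on an aromatic carbon. Among the compounds with values here, no measured step concerns removing a bromo group, so compound 3 is estimated at 170000 nM, between 70000 nM and 400000 nM, a step of an at least 1.2-fold lower number from compound 2 to compound 3 (0.10 log units; that floor lies within the scatter) expected to stay within the scatter.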

Compound 3, half-maximal cytotoxic concentration: 24000 nM
Compound 3: the middle estimate sits 7.1-fold (0.85 log units) above what was measured, outside the stated range (below it).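

In this assay, the bromo group on this aromatic carbon proves to matter: replacing it with hydrogen gives an at least 9.0-fold lower number from compound 2 to compound 3 (0.95 log units; beyond the scatter), and the lower number stands for higher toxicity in this test. Compound 2 stands at a limit of the assay and not at a number, so this step is only a floor: the limit of > 216000 nM in this assay, at which 1 of the 3 values shown sits. Without the bromo group, the order against the 1,3-thiazol-2-yl compound turns around, with a 3.7-fold lower number from compound 1 to compound 3 (0.56 log units; beyond the scatter). From the compounds shown here alone, whether chloro, methoxy or an amine on this same carbon would keep the number as high as bromo does remains open.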